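Phenyl in place of ethyl: a clearance estimate

The source may report more compounds than this note shows. Statements on the series, on what has been measured and on what is new or still open speak of the compounds shown alone.

Compound 2 `CCN1C(=O)c2ccccc2S1(=N)=O` gives < 3 mL.min-1.g-1 in an ADME assay on microsomes from liver (Homo sapiens) for metabolic stability (on this read-out higher numbers stand for fast clearance and lower numbers for slow clearance), and this is a limit of the assay and not a number. Compound 1 `N=S1(=O)c2ccccc2C(=O)N1Cc1ccccc1` gives 19.2 mL.min-1.g-1 in this assay. Compound 3 `N=S1(=O)c2ccccc2C(=O)N1c1ccccc1` is the next to be measured, and it has phenyl in place of ethyl on an amide-type nitrogen in a ring, next to the ring sulfur: phenyl in place of ethyl on an amide-type nitrogen in a ring. Within the data shown here, one measured step bears on this change. It is an at least 6.4-fold lower number from compound 1 to compound 2 (0.80 log units; beyond the scatter), with methyl in place of phenyl on a saturated chain carbon bound to an amide-type nitrogen in a ring. That step lost a phenyl and the number fell, so adding a phenyl is expected to raise it. The guide is only partial, since the phenyl of compound 3 sits directly on the nitrogen and the starting point is a limit. A rise of modest size, probably beyond the scatter, is therefore expected, and the expected step is an at least 2.6-fold higher number from compound 2 to compound 3 (0.42 log units; beyond the scatter). For compound 3 the estimated value is 8 mL.min-1.g-1, with an expected range from 3 mL.min-1.g-1 to 22 mL.min-1.g-1.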

Compound 3, intrinsic clearance in microsomes in the liver assay: 93.5 mL.min-1.g-1
For compound 3 the middle estimate is 12-fold (1.07 log units) below the measured one, and the stated range ends below it.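

In the liver assay, phenyl in place of ethyl on an amide-type nitrogen in a ring gives an at least 31-fold higher number from compound 2 to compound 3 (1.49 log units; beyond the scatter), a large step that shows how strongly the read-out responds to the group at this place, and compound 3 at 93.5 mL.min-1.g-1 also stands above compound 1 at 19.2 mL.min-1.g-1, so a phenyl on this nitrogen goes with a higher number than a phenyl on a saturated chain carbon bound to it. In the liver assay compound 2 gives < 3 mL.min-1.g-1, a limit of the assay and not a number. In a physicochemical assay for lipophilicity, at pH 7.4 (on this read-out lower numbers stand for lower lipophilicity and higher numbers for higher lipophilicity), compound 2 gives 0.7 and compound 3 gives 1.3. In the physicochemical assay the same change also raises the number, so higher lipophilicity may contribute to the faster clearance, although the modest size of this step leaves its share uncertain: the measured distribution coefficient of compound 2, 0.7, and of compound 3, 1.3, a number 0.60 log units higher (beyond the scatter)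

The compounds shown leave open whether the rise belongs to an aromatic ring on this nitrogen or merely to a larger group, a question that a cyclohexyl or a pyridine ring at the same place would address. They also leave open whether a fluorine or a methoxy group on the phenyl would shift the clearance of compound 3.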